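A few compounds are considered here, and "the series" means these few. Any claim that something is new, unique, unknown or untested is made for them only; others in the source may bear on it.

In a functional assay on COLO 205 cells (Homo sapiens) for cytotoxicity, read by sulforhodamine B assay, with a stated time of 48 h (on this read-out lower numbers stand for stronger inhibition and higher numbers for weaker inhibition), three compounds with a shared core have been measured. Compound 1 `COc1cc(/C=C/C(=O)/C=C/c2cccc3ccccc23)ccc1OCc1cn(CCOc2cc(=O)oc3ccccc23)nn1` gives 9950 nM, compound 2 `COc1cccc(/C=C/C(=O)/C=C/c2ccc(OCc3cn(CCOc4cc(=O)oc5ccccc45)nn3)c(OC)c2)c1` gives 11900 nM, and compound 3 `COc1ccc(/C=C/C(=O)/C=C/c2ccc(OCc3cn(CCOc4cc(=O)oc5ccccc45)nn3)c(OC)c2)cc1OC` gives 6780 nM. Compound 3 is thus not separated from either of the other two, as a 1.5-fold lower number from compound 1 to compound 3 (0.17 log units; within the scatter) and a 1.8-fold lower number from compound 2 to compound 3 (0.24 log units; within the scatter) both show.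

The next compound, compound 4 `COc1cc(/C=C/C(=O)/C=C/c2ccco2)ccc1OCc1cn(CCOc2cc(=O)oc3ccccc23)nn1`, carries furan-2-yl in place of 3,4-dimethoxyphenyl on a double-bonded chain carbon bound to a double-bonded chain carbon. Two measured steps replace the group at this same place: a 1.2-fold higher number from compound 1 to compound 2 (0.08 log units; within the scatter) and a 1.5-fold lower number from compound 1 to compound 3 (0.17 log units; within the scatter). A third, a 1.8-fold lower number from compound 2 to compound 3 (0.24 log units; within the scatter), adds a single methoxy to that group. None of these steps leaves the scatter, even though naphthalen-1-yl, 3-methoxyphenyl and 3,4-dimethoxyphenyl were exchanged. Within the data shown here, no measured compound carries furan-2-yl, however, so this expectation is an extrapolation and the range must stay wide. No step beyond the scatter is therefore expected in this assay, and no firm direction can be given, with the estimated step being a 1.3-fold higher number from compound 3 to compound 4 (0.12 log units; within the scatter). For compound 4 the expected value is 9000 nM, with an estimated range from 4000 nM to 20000 nM.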

Compound 4, half-maximal inhibitory concentration: 11800 nM
The estimate for compound 4 lay 1.3-fold (0.12 log units) below the measured number; measured number inside the range.
By their numbers in this assay, from the lowest: compounds 3, 1, 4 and 2 (each within the scatter of the next).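

In this assay, furan-2-yl brings a five-membered aromatic ring with 1 hetero atom to the place on a double-bonded chain carbon bound to a double-bonded chain carbon, and the exchange stays within the scatter against all three earlier groups: a 1.7-fold higher number from compound 3 to compound 4 (0.24 log units; within the scatter), a 1.0-fold lower number from compound 2 to compound 4 (0.00 log units; within the scatter) and a 1.2-fold higher number from compound 1 to compound 4 (0.07 log units; within the scatter). Even the step from 3,4-dimethoxyphenyl, which goes from 10 heavy atoms to 5 and from 2 hydrogen-bond acceptors to 1, therefore separates no compounds, so the tolerance seen among the earlier groups now extends to a smaller ring with a hetero atom. Nothing at hand gives a reason for this result.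

From the compounds shown here alone, all four compounds carry an aromatic ring at this place, so it remains open whether a non-aromatic group, such as a simple amine or a carboxylic acid, would move the number beyond the scatter. Going by these compounds, it also remains open whether a change elsewhere on the shared core would do so, since all four compounds differ only at this one place.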